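The source may report more compounds than this note shows. Statements on the series, on what has been measured and on what is new or still open speak of the compounds shown alone.

Compound 3 `Cc1cccc(N2CC(c3nc(-c4cccc(Cl)c4)no3)CC2=O)c1` was tested in an in vitro functional assay on HEK293-A cells for negative allosteric modulation of metabotropic glutamate receptor 5 (Homo sapiens), read by FLIPR and calcium flux (a higher number here means a weaker inhibitor, a lower number a stronger inhibitor), where compound 3 gives 2300 nM. Among the compounds that return a number, compound 3 stands highest: compound 2 `O=C1CC(c2nc(-c3cccc(Cl)c3)no2)CN1c1ccccc1Cl` gives 680 nM in this assay. Compound 1 `O=C1CC(c2nc(-c3cccc(Cl)c3)no2)CN1c1ccc(Cl)cc1` gives only a limit of the assay in this assay, > 10000 nM. The three share one core and differ only in the aryl group on an amide-type nitrogen in a ring. Putting 2-chlorophenyl in place of 4-chlorophenyl gave an at least 14-fold lower number from compound 1 to compound 2 (1.16 log units; beyond the scatter), putting 3-methylphenyl in place of 4-chlorophenyl gave an at least 4.3-fold lower number from compound 1 to compound 3 (0.63 log units; beyond the scatter), and 3-methylphenyl in place of 2-chlorophenyl gave a 3.4-fold higher number from compound 2 to compound 3 (0.53 log units; beyond the scatter).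

Compound 4 `Cc1ccc(N2CC(c3nc(-c4cccc(Cl)c4)no3)CC2=O)cc1C` has not yet been measured. Compared with compound 3 it carries methyl in place of hydrogen on an aromatic carbon, so the 3-methylphenyl becomes 3,4-dimethylphenyl. Among the measured compounds shown here, no measured step adds a group to an already substituted aryl, so the three steps bear on it only loosely; the one compound whose aryl is 4-chlorophenyl, compound 1, sits at the limit of > 10000 nM in this assay, at which 1 of the 3 values shown sits. A modest weakening is therefore expected for compound 4, with a 2.0-fold higher number from compound 3 to compound 4 (0.29 log units; within the scatter) in this assay. Compound 4 is estimated at 4500 nM, between 1500 nM and 13000 nM.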

Compound 4, half-maximal inhibitory concentration: > 10000 nM
Compound 4: a limit, no number (the forecaster's own chance of this, stated with the estimate: 25%); middle value at least 2.2-fold (0.34 log units) away from the limit.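

Adding one methyl to the aryl of compound 3, on the aromatic carbon ortho to a methyl group and para to a large group, gave an at least 4.3-fold higher number from compound 3 to compound 4 (0.63 log units; beyond the scatter) in this assay, the first step shown in which a group is added to an aryl that keeps its existing substituent, so the loss can be tied to this one position. Compound 4 also falls well short of the best aryl shown, with 3,4-dimethylphenyl in place of 2-chlorophenyl giving an at least 14-fold higher number from compound 2 to compound 4 (1.16 log units; beyond the scatter); the step between compound 1 and compound 4 cannot be read, as both values are limits. Compound 4 gives a limit of the assay and not a number, and the two compounds that carry a group at this ring position, compound 1 with its chlorine and compound 4 with its methyl, read alike:  the limit of > 10000 nM in this assay, at which 2 of the 4 values shown sit.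

Going by these compounds, how far past that limit either compound lies stays open, so chlorine and methyl cannot be ranked at this position. Also open, on these data alone, are whether a fluorine, a hydroxyl or a methoxy group would be received there any better, and whether the same added methyl would cost as much on the 2-chlorophenyl of compound 2.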